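Cytotoxicity across ester side chains: compound 2 to compound 3

A few compounds are considered here, and "the series" means these few. Any claim that something is new, unique, unknown or untested is made for them only; others in the source may bear on it.

Measured in an ADME assay on HepG2 2.2.15 cells (Homo sapiens) for cytotoxicity; on this read-out lower numbers stand for higher toxicity in this test and higher numbers for lower toxicity in this test:
- Compound 1 `CCOCC(=O)OCCc1c(-c2ccccc2Cl)c2cc(Cl)ccc2[nH]c1=O`: 130000 nM
- Compound 2 `O=C(CCOc1ccccc1)OCCc1c(-c2ccccc2Cl)c2cc(Cl)ccc2[nH]c1=O`: 46000 nM

Among the compounds with values here, compound 2 holds the lower of the two numbers so far, and compound 1 is its only neighbour. The next compound, compound 3 `O=C(/C=C/c1cccc(C(F)(F)F)c1)OCCc1c(-c2ccccc2Cl)c2cc(Cl)ccc2[nH]c1=O`, is not yet measured. It carries 2-(3-(trifluoromethyl)phenyl)ethenyl in place of 2-phenoxyethyl on a carbonyl carbon.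

Within the data shown here, only one measured step bears on this change: a 2.8-fold lower number from compound 1 to compound 2 (0.45 log units; beyond the scatter). There, phenoxymethyl replaced ethoxy on a saturated chain carbon bound to a carbonyl carbon. Among the measured compounds shown here, this single modest step is a thin guide, and no measured compound carries the entering group. A step of similar size towards a lower number in this assay is therefore expected, and the estimated step is a 2.3-fold lower number from compound 2 to compound 3 (0.36 log units; beyond the scatter). For compound 3 the expected value is 20000 nM, with an estimated range of 7000 nM to 60000 nM.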

Compound 3, half-maximal cytotoxic concentration: > 1400000 nM
Compound 3 gave a limit, no number; the forecaster's own chance of this, stated with the estimate: 10%; middle value at least 70-fold (1.84 log units) away from the limit.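

In this assay, the side chain on the carbonyl carbon moves the read-out upward as well as downward: 2-(3-(trifluoromethyl)phenyl)ethenyl gives an at least 30-fold higher number from compound 2 to compound 3 (1.48 log units; beyond the scatter), and in place of ethoxymethyl it gives an at least 10-fold higher number from compound 1 to compound 3 (1.03 log units; beyond the scatter). Compound 3 gives a limit, not a number, so the full size of both steps stays unknown: the limit of > 1400000 nM in this assay, at which 1 of the 3 values shown sits.

The single earlier step therefore did not carry over to this change, and among these three compounds the direction of the step depends on the entering group.

The compounds shown do not separate the contributions of the ethenyl link, the trifluoromethyl group and the aromatic ring. From the compounds shown here alone, how a side chain ending in an amine or a carboxylic acid would read in this assay also stays open.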